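Replacing fluoro with methoxy in a weakly cytotoxic pair

The compounds below may be only part of what the source reports. "The series", "measured", "known", "first", "only" and "open" are said of these compounds alone.

In a functional assay on PC-3 cells (Homo sapiens) for cytotoxicity, read by MTT assay, with a stated time of 72 h (a lower number here means a stronger inhibitor, a higher number a weaker inhibitor), compound 1 `CNC(=O)c1cc(Oc2ccc(NC(=O)c3cc(-c4ccc(C)cc4)ncn3)cc2F)ccn1` gives 40200 nM. Compound 2 `CNC(=O)c1cc(Oc2ccc(NC(=O)c3cc(-c4ccc(F)cc4)ncn3)cc2F)ccn1` reads > 100000 nM, which is a limit of the assay and not a number. Compound 3 `CNC(=O)c1cc(Oc2ccc(NC(=O)c3cc(-c4ccc(OC)cc4)ncn3)cc2F)ccn1` differs from compound 2 by methoxy in place of fluoro on an aromatic carbon, with 4-fluorophenyl becoming 4-methoxyphenyl. Within the data shown here, only one measured step bears on this change: an at least 2.4-fold higher number from compound 1 to compound 2 (0.39 log units; beyond the scatter), where fluoro took the place of methyl. Losing fluoro again, this time to methoxy, is expected to bring a modest move to a lower number in this assay, an estimated at least 2.0-fold lower number from compound 2 to compound 3 (0.30 log units; that floor lies within the scatter). For compound 3 the expected value is 50000 nM, with an estimated range of 15000 nM to 100000 nM.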

Compound 3, half-maximal inhibitory concentration: 56200 nM
For compound 3 the middle estimate is 1.1-fold (0.05 log units) below the measured one, within the range that was stated.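

In this assay methoxy at this place gives a measurable value where fluoro does not, yet the floor of the step (an at least 1.7-fold lower number from compound 2 to compound 3 (0.25 log units; that floor lies within the scatter)) lies within the scatter, so no firm gain can be claimed. Compound 2 stands at a limit, which is not a number: the limit of > 100000 nM in this assay, at which 1 of the 3 values shown sits. Methoxy and methyl cannot be told apart here (a 1.4-fold higher number from compound 1 to compound 3 (0.15 log units; within the scatter)).

From the compounds shown here alone, how far fluoro truly lies from methoxy stays open, with only a limit for compound 2. Going by these compounds, what an amine or a carboxylic acid would give at this place is also open.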